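The source may hold more compounds than are shown below. What is called first, only, known or untested is meant among the compounds shown, and "the series" means these compounds.

Compound 2 `COc1ccc(C(=O)/C=C/c2cc(-c3cc(OC)c(OC)c(OC)c3)n[nH]2)cc1OC` stands lowest of the two values in hand: in a functional assay on A549 cells (Homo sapiens) for cytotoxicity, read by sulforhodamine B assay, with a stated time of 48 h, tested at 10 uM (on this read-out lower numbers stand for a stronger effect and higher numbers for a weaker effect at the one concentration tested), compound 2 gives -43%, whereas compound 1 `COc1cc(-c2cc(/C=C/C(=O)c3ccc(N)cc3)[nH]n2)cc(OC)c1OC` gives -15%. Among the compounds with values here, the single measured step, a number 28 percentage points lower from compound 1 to compound 2 (beyond the scatter), concerns the aryl on the carbonyl carbon, the same ring that is altered in compound 3 `COc1ccc(C(=O)/C=C/c2cc(-c3cc(OC)c(OC)c(OC)c3)n[nH]2)cc1`. The change there is hydrogen in place of methoxy on an aromatic carbon, a 3,4-dimethoxyphenyl to 4-methoxyphenyl cut that is smaller than the measured swap. The estimated step is therefore a number 13 percentage points higher from compound 2 to compound 3 (beyond the scatter), likely within the scatter, leaning toward a slightly weaker effect. Compound 3 is expected to give -30%, with a range of -60% to 0%.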

Compound 3, a percentage reported as activity, at one concentration (the size of the read-out at that concentration, not a potency): -15%
Compound 3: the middle estimate sits 15 percentage points below what was measured; the measured number falls inside the stated range.
By their numbers in this assay, from the lowest: compound 2; then compounds 1 and 3 (each within the scatter of the next).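

In this assay, hydrogen in place of methoxy on the 3,4-dimethoxyphenyl ring gives a number 28 percentage points higher from compound 2 to compound 3 (beyond the scatter) and so cancels the whole gain of the earlier swap with one methoxy, the one ortho to a methoxy group. Methoxy in place of amino on an aromatic carbon gives no change at the digits printed from compound 1 to compound 3 (within the scatter) and leaves the 4-methoxyphenyl and 4-aminophenyl compounds level. Nothing in hand explains either step. The compounds shown leave open whether this carbon needs methoxy itself or any group there, as a hydroxy, a chlorine or an ethoxy would show.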